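Acyl Group Variation and Maximal Response on a Shared Core

A few compounds are considered here, and "the series" means these few. Any claim that something is new, unique, unknown or untested is made for them only; others in the source may bear on it.

Measured compounds:
compound 1 `CCC(=O)N1CC2CC(C1)N2` 120%
compound 2 `CC(C)C(=O)N1CC2CC(C1)N2` 45%
compound 3 `O=C([C@H]1C[C@@H]1F)N1CC2CC(C1)N2` 85%

In an assay on CHO cells for agonist activity at Neuronal acetylcholine receptor; alpha3/alpha6/beta2/beta3 (Homo sapiens), read by FLIPR and calcium flux (a lower number here means a smaller maximal response, a higher number a larger maximal response), compound 1 gives 120%, the highest of the three measured numbers; compound 3 stands nearest with 85%, and compound 2 furthest with 45%. Compound 4, `C[C@@H]1C[C@@H]1C(=O)N1CC2CC(C1)N2`, has not yet been measured. Relative to compound 1 it carries a group of 4 heavy atoms (4 carbon; one three-membered non-aromatic ring of carbon only) in place of a group of 2 heavy atoms (2 carbon; no ring), on a carbonyl carbon. Among the measured compounds shown here, two measured steps bear on this change. Exchanging ethyl for 2-fluorocyclopropyl on the carbonyl carbon gave a number 35 percentage points lower from compound 1 to compound 3 (beyond the scatter), and methyl in place of hydrogen on the saturated chain carbon bound to the carbonyl carbon gave a number 75 percentage points lower from compound 1 to compound 2 (beyond the scatter). Both steps lowered the maximal response, so a drop beyond the scatter is expected for compound 4, estimated as a number 50 percentage points lower from compound 1 to compound 4 (beyond the scatter). Compound 4 is therefore expected to give 70%, within a range of 40% to 100%.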

Compound 4, largest response reached (Emax), in percent of the reference or control that the assay uses: 87%
Beside the measured number, compound 4's estimate is 17 percentage points below it; measured number inside the range.
By their numbers in this assay, from the lowest: compound 2; then compounds 3 and 4 (each within the scatter of the next); then compound 1.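

In this assay, removing the fluorine from the three-membered ring changes little: a number 2 percentage points higher from compound 3 to compound 4 (within the scatter). The all-carbon ring group still stands apart from the open chains on the carbonyl carbon, with a number 33 percentage points lower from compound 1 to compound 4 (beyond the scatter) and a number 42 percentage points higher from compound 2 to compound 4 (beyond the scatter). So, among these compounds, a substituted three-membered ring gives a response that lies between those of ethyl and isopropyl, whichever of the two substituents it carries. Nothing available here explains these differences. 

As far as these compounds go, how an unsubstituted cyclopropyl group, a butyl chain or an acyl group bearing an amine would respond remains open. So does the effect of the opposite stereochemistry on the ring.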